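Sulfonyl aryl swap in a series sitting at the limit

This account rests on a few compounds, and the source may have more. Where it says the series, first, only, none or still open, it means among the compounds named here.

Compound 3 `CCN(CC)C(=O)CN(c1ccc(C)cc1)S(=O)(=O)c1ccc(C#N)cc1` in a functional assay on CHO cells for inhibition of Orexin/Hypocretin receptor type 1 (Homo sapiens), read by FLIPR and calcium flux (on this read-out lower numbers stand for stronger inhibition and higher numbers for weaker inhibition), gives > 10000 nM, which is a limit of the assay rather than a number. Compound 1 `CCN(CC)C(=O)CN(c1ccc(C)cc1)S(=O)(=O)c1ccc(OC(F)(F)F)cc1` in this assay gives > 10000 nM, also a limit. Compound 2 `CCN(CC)C(=O)CN(c1ccc(C)cc1)S(=O)(=O)c1cccc(Cl)c1` in this assay gives > 10000 nM, again a limit. The step from compound 1 to compound 3 is a step that the two limits leave unreadable from compound 1 to compound 3 and the step from compound 2 to compound 3 is a step that the two limits leave unreadable from compound 2 to compound 3 because of the limit of > 10000 nM in this assay, at which 3 of the 3 values shown sit. For the measured compounds named here, compound 3 thus stands at the limit together with every other measured member, and no step among them can be read.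

Compound 4 `CCN(CC)C(=O)CN(c1ccc(C)cc1)S(=O)(=O)c1ccccc1F` differs from compound 3 by 2-fluorophenyl in place of 4-cyanophenyl on a sulfonyl sulfur. The two measured steps bear on it only in kind, as each also exchanges the aryl group on the sulfonyl sulfur, and both are unreadable, so they fix neither direction nor size. With all values at the limit, the step in this assay from compound 3 to compound 4 is expected to remain unreadable too. Compound 4 is therefore expected to give about 15000 nM in this assay, within a range from 4000 nM to 60000 nM, most likely reported only as a limit. The expected step is a step that the limit leaves unreadable from compound 3 to compound 4.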

Compound 4, half-maximal inhibitory concentration: > 10000 nM
Compound 4 ended at the assay's limit; the forecaster's own chance of this, stated with the estimate: 80%; the middle value is on the limit's open side.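

In this assay no new step can be read for compound 4 against compound 2 or compound 3, as all sit at a limit: the limit of > 10000 nM in this assay, at which 4 of the 4 values shown sit. Still open, as far as these compounds go, is whether any aryl group on the sulfonyl sulfur gives a readable inhibition value on the shared core.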